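A few compounds are considered here, and "the series" means these few. Any claim that something is new, unique, unknown or untested is made for them only; others in the source may bear on it.

Of the compounds shown here, three that share one core have been measured so far in an in vitro ADME assay on microsomes from liver (Simiiformes); on this read-out higher numbers stand for a longer-lived compound and lower numbers for a shorter-lived compound. Compound 1 `Cc1cc(CCCOc2c(C)cc(-c3noc(C(N)=O)n3)cc2C)on1`, which carries carbamoyl, gives 2.3 h. Compound 2 `Cc1cc(CCCOc2c(C)cc(-c3noc(C(Cl)(Cl)Cl)n3)cc2C)on1`, with trichloromethyl in its place, gives 0.183 h. Compound 3 `COc1nc(-c2cc(C)c(OCCCc3cc(C)no3)c(C)c2)no1`, with methoxy there, gives 0.55 h, the middle of the three numbers.

Compound 4 `CCOc1nc(-c2cc(C)c(OCCCc3cc(C)no3)c(C)c2)no1` turns that methoxy into ethoxy: methyl in place of hydrogen on a saturated chain carbon bound to an oxygen on an aromatic ring.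

The measured steps all exchange one whole group for another on an aromatic carbon. Trichloromethyl in place of carbamoyl gives a 13-fold lower number from compound 1 to compound 2 (1.10 log units; beyond the scatter), a large step. Methoxy in place of carbamoyl gives a 4.2-fold lower number from compound 1 to compound 3 (0.62 log units; beyond the scatter), and methoxy in place of trichloromethyl gives a 3.0-fold higher number from compound 2 to compound 3 (0.48 log units; beyond the scatter), both modest. Going by the values given here, all three lie beyond the scatter, but none of them lengthens a chain, so the data hold no direct precedent for this change.

Even the exchange of whole groups in a 3.0-fold higher number from compound 2 to compound 3 (0.48 log units; beyond the scatter) stayed modest, so the far smaller edit here is expected to give no step beyond the scatter in this assay. The expected change is a 1.1-fold lower number from compound 3 to compound 4 (0.06 log units; within the scatter). For compound 4 the estimated half-life is 0.48 h, with a likely range from 0.22 h to 1 h.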

Compound 4, half-life: > 2.5 h
Compound 4 gave a limit, no number; the forecaster's own chance of this, stated with the estimate: 3%; middle value at least 5.2-fold (0.71 log units) away from the limit.
By their numbers in this assay, from the lowest: compound 2; then compound 3; then compound 1. At a limit, above all of these: compound 4.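

In this assay compound 4 gives > 2.5 h, which is a limit of the assay and not a number. Even read only as a floor, the added methyl on a saturated chain carbon bound to an oxygen on an aromatic ring, which turns methoxy into ethoxy, gives an at least 4.5-fold higher number from compound 3 to compound 4 (0.65 log units; beyond the scatter), so this position answers to a very small edit and not only to the exchange of whole groups seen in the earlier compounds. Ethoxy also gives an at least 13-fold higher number from compound 2 to compound 4 (1.13 log units; beyond the scatter), while the comparison with the carbamoyl compound gives only an at least 1.0-fold higher number from compound 1 to compound 4 (0.03 log units; that floor lies within the scatter), so compound 4 cannot yet be placed firmly against compound 1, the longest-lived of the compounds with a true number.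

The limit hides how far the half-life of compound 4 really reaches, and nothing shown explains why a single methyl at this place matters so much. On these data alone, it also remains open whether a longer chain such as propoxy, or a branched group such as isopropoxy, would carry the half-life further or lose what ethoxy gave.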